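The source may hold more compounds than are shown below. What is called first, only, known or untested is meant among the compounds shown, and "the series" means these compounds.

Measured so far in a physicochemical assay for solubility, read by spectrophotometry, in phosphate buffer, with a stated time of 2 h, at pH 7.4; on this read-out higher numbers stand for higher solubility and lower numbers for lower solubility:
compound 1 `COc1ccc2[nH]c(C(=O)N3CC(=O)N(Cc4ccccc4)[C@@H](CN4CCCC4)C3)cc2c1`: > 25000 nM
compound 2 `COc1ccc2[nH]c(C(=O)N3CC(=O)N(Cc4cccc(OC(F)F)c4)[C@@H](CN4CCC(C#N)CC4)C3)cc2c1`: 27900 nM
compound 3 `COc1ccc2[nH]c(C(=O)N3CC(=O)N(Cc4cccc(OC(F)F)c4)[C@@H](CN4CC5CCC4C5)C3)cc2c1`: 62000 nM

Compound 1 sits at a limit of this assay, (the limit of > 25000 nM in this assay, at which 1 of the 3 values shown sits), so no number is known for it; the other two values are numbers. Compound 4 `COc1ccc2[nH]c(C(=O)N3CC(=O)N(Cc4ccccc4)[C@@H](CN4CCc5ccccc5C4)C3)cc2c1` differs from compound 1 by 1,2,3,4-tetrahydroisoquinolin-2-yl in place of pyrrolidin-1-yl on a saturated chain carbon bound to a saturated ring carbon. Going by the values given here, the only measured step at this place is a 2.2-fold higher number from compound 2 to compound 3 (0.35 log units; beyond the scatter), a modest rise on swapping one saturated amine ring for another. Among the compounds with values here, the change to compound 4 is of a different kind, since a six-membered aromatic ring of carbon only enters, and no measured pair shows that. For compound 4 the expectation is therefore a step of an at least 1.6-fold lower number from compound 1 to compound 4 (0.22 log units; that floor lies within the scatter), small and uncertain in direction, giving an estimated solubility of 15000 nM in this assay, within 4000 nM to 50000 nM.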

Compound 4, solubility: 9000 nM
For compound 4 the middle estimate is 1.7-fold (0.22 log units) above the measured one; low and high end bracket the measured number.
By their numbers in this assay, from the lowest: compound 4; then compound 2; then compound 3.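

In this assay, going by these compounds alone, 1,2,3,4-tetrahydroisoquinolin-2-yl in place of pyrrolidin-1-yl on a saturated chain carbon bound to a saturated ring carbon gives an at least 2.7-fold lower number from compound 1 to compound 4 (0.44 log units; beyond the scatter), so this place can also move the number down, whereas the only earlier step here was upward, a 2.2-fold higher number from compound 2 to compound 3 (0.35 log units; beyond the scatter). Compound 1 carries only a limit, so the size of the new step is a floor: the limit of > 25000 nM in this assay, at which 1 of the 4 values shown sits.

Open, going by these compounds, is whether the lower number goes with the six-membered aromatic ring or with the larger group alone. On the core of compound 1, a saturated decahydroisoquinolin-2-yl group would separate the two.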